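Acetamido in place of nitro: expected cytotoxicity of compound 4

The source may report more compounds than this note shows. Statements on the series, on what has been measured and on what is new or still open speak of the compounds shown alone.

Compound 1 `O=[N+]([O-])c1ccc(-c2nc3cc(Cl)c(Cl)cc3[nH]2)cc1` is measured in an ADME assay on MDBK cells (Bos taurus) for cytotoxicity, read by MTT assay, with a stated time of 96 h (on this read-out higher numbers stand for lower toxicity in this test and lower numbers for higher toxicity in this test), at 56000 nM, the highest of the two numbers reported, while compound 2 `O=C(CCl)Nc1ccc(-c2nc3cc(C(F)(F)F)ccc3[nH]2)cc1` gives 17000 nM, a gap beyond the scatter. For compound 3 `CCC(=O)Nc1ccc(-c2nc3cc(C(F)(F)F)ccc3n2C)cc1` this assay reports only a limit, > 100000 nM, which is the limit of > 100000 nM in this assay, at which 1 of the 3 values shown sits. Compound 4 `CC(=O)Nc1ccc(-c2nc3cc(Cl)c(Cl)cc3[nH]2)cc1` is not yet measured in this assay; it differs from compound 1 by acetamido in place of nitro on an aromatic carbon. For the measured compounds named here, no step between measured compounds isolates this change, so the direction rests on the spread of the three values. A moderate rise, beyond the scatter, is expected from compound 1 to compound 4: a 1.5-fold higher number from compound 1 to compound 4 (0.18 log units; within the scatter). Compound 4 is therefore estimated at 85000 nM, within 30000 nM to 200000 nM, with a fair chance that only a limit is returned.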

Compound 4, half-maximal cytotoxic concentration: 58000 nM
Estimate against measurement, compound 4: 1.5-fold (0.17 log units) above, within the range that was stated.
By their numbers in this assay, from the lowest: compound 2; then compounds 1 and 4 (each within the scatter of the next). At a limit, above all of these: compound 3.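

In this assay the first step read at this position is a 1.0-fold higher number from compound 1 to compound 4 (0.02 log units; within the scatter), so on this core, on an aromatic carbon para to a large group, acetamido and nitro cannot be told apart. The earlier compounds shown here gave no step at this position, only values on cores that differ in more than one place. Nothing measured here bears on why the exchange gives no change beyond the scatter. Open, from the compounds shown here alone, is whether an amine or a carboxylic acid in the same place would also stay within the scatter, and whether a longer amide chain would.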